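The source may hold more compounds than are shown below. What is called first, only, known or untested is meant among the compounds shown, and "the series" means these compounds.

Compound 1 `CCCCCCc1cc2c(=O)n(CCSc3nc(-c4cc(OC)c(OC)c(OC)c4)c(C#N)c(=O)[nH]3)cnc2s1`: 76.3 ug/mL
Compound 2 `CCCc1cc2c(=O)n(CCCSc3nc(-c4cc(OC)c(OC)c(OC)c4)c(C#N)c(=O)[nH]3)cnc2s1`: 52.5 ug/mL

In an ADME assay on HeLa cells (Homo sapiens) for inhibition, read by MTT assay (a lower number here means a stronger inhibitor of growth, a higher number a weaker inhibitor of growth), compound 1 gives the larger of the two numbers, but compound 2 sits within the scatter of it, so the two are not told apart. Compound 3 `CCCCCCCc1cc2c(=O)n(CCSc3nc(-c4cc(OC)c(OC)c(OC)c4)c(C#N)c(=O)[nH]3)cnc2s1` has not been measured. It differs from compound 1 by methyl in place of hydrogen on a saturated chain carbon, six bonds along the chain from an aromatic carbon. For the measured compounds named here, no step between measured compounds shows what such a change does, so the step from compound 1 to compound 3 is expected to be small, a 1.2-fold lower number from compound 1 to compound 3 (0.07 log units; within the scatter), and not clearly beyond the scatter. Compound 3 is therefore estimated at 65 ug/mL, within a range from 30 ug/mL to 140 ug/mL.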

Compound 3, concentration for 50% growth inhibition: 75.4 ug/mL
Compound 3: the middle estimate sits 1.2-fold (0.06 log units) below what was measured, and the stated range covers the measured number.
By their numbers in this assay, from the lowest: compounds 2, 3 and 1 (each within the scatter of the next).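

In this assay, methyl in place of hydrogen on a saturated chain carbon, six bonds along the chain from an aromatic carbon, gives a 1.0-fold lower number from compound 1 to compound 3 (0.01 log units; within the scatter). For the compounds shown here, this is the first step read between measured compounds at this position, and it leaves compound 1 and compound 3 not told apart. Nothing at hand gives a reason for this result. From the compounds shown here alone, whether a much longer chain, an amine or a carboxylic acid at this place would move the number beyond the scatter stays open.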